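This account rests on a few compounds, and the source may have more. Where it says the series, first, only, none or still open, it means among the compounds named here.

Measured in a functional assay on HCC827 cells (Homo sapiens) for inhibition, read by fluorescence, with a stated time of 72 h; on this read-out higher numbers stand for weaker inhibition of growth and lower numbers for stronger inhibition of growth:
- compound 1 `COc1ccc(Cn2cnc3c(Nc4cccc(Cl)c4)nc(N[C@H]4CC[C@H](N)CC4)nc32)cc1`: 18700 nM
- compound 2 `CCCCn1cnc2c(Nc3cc(OC)cc(OC)c3)nc(N[C@H]3CC[C@H](N)CC3)nc21`: 20100 nM
- compound 3 `CC(C)CCn1cnc2c(Nc3ccccc3)nc(N[C@H]3CC[C@H](N)CC3)nc21`: 21700 nM

These three values lie within the usual scatter of one another, so compound 1 cannot be told apart from compound 2 or compound 3 in this assay. Within the data shown here, all three sit in the same narrow band, and no pair among them differs in only one place.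

Compound 4 `CC(C)=CCC/C(C)=C/Cn1cnc2c(Nc3cccc(Cl)c3)nc(N[C@H]3CC[C@H](N)CC3)nc21` keeps the core of compound 1 and changes a single group: 2,6-dimethylhepta-1,5-dien-1-yl in place of 4-methoxyphenyl on a saturated chain carbon bound to an aromatic nitrogen. Cut one bond further out, this reads as 4-methoxybenzyl to 3,7-dimethylocta-2,6-dien-1-yl, so a group containing a ring gives way to an open chain.

The closest evidence is indirect. Compound 2 at 20100 nM and compound 3 at 21700 nM both carry an open chain at that place, yet neither stands apart from compound 1. Both also differ from compound 1 elsewhere, so this swap has not been measured on its own. The expected change, a 1.3-fold lower number from compound 1 to compound 4 (0.13 log units; within the scatter), is therefore small, with no shift beyond the scatter anticipated. For compound 4 the estimated value is 14000 nM, with an expected range from 5000 nM to 28000 nM.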

Compound 4, concentration for 50% growth inhibition: 18200 nM
For compound 4 the middle estimate is 1.3-fold (0.11 log units) below the measured one, and the stated range covers the measured number.
By their numbers in this assay, from the lowest: compounds 4, 1, 2 and 3 (each within the scatter of the next).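

In this assay, replacing 4-methoxybenzyl with 3,7-dimethylocta-2,6-dien-1-yl, with the rest of the molecule unchanged, gives a 1.0-fold lower number from compound 1 to compound 4 (0.01 log units; within the scatter). This shows directly what compounds 2 and 3 could only hint at, since they also differ from compound 1 elsewhere: on a saturated chain carbon bound to an aromatic nitrogen, 4-methoxyphenyl, with its aromatic ring and one hydrogen-bond acceptor, can give way to 2,6-dimethylhepta-1,5-dien-1-yl, with no ring and no hydrogen-bond acceptor, without a shift beyond the scatter. No measurement at hand explains why these two different groups give such similar numbers.

As far as these compounds go, because all four compounds sit in one narrow band, it remains open whether any group at this place can move the number beyond the scatter, such as a small methyl group, a chain ending in an amine or one ending in a carboxylic acid. From the compounds shown here alone, it is also open whether the same swap would read alike with the other groups carried by compound 2 or compound 3 elsewhere on the molecule.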